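Chain variation on the aromatic nitrogen of the shared core

A few compounds are considered here, and "the series" means these few. Any claim that something is new, unique, unknown or untested is made for them only; others in the source may bear on it.

Measured compounds:
compound 1 `CCCCCCn1c(N2CCN(C)CC2)nc2ccccc21`, 26 nM
compound 2 `CCCSCn1c(N2CCN(C)CC2)nc2ccccc21`, 68 nM
compound 3 `CCCCCCCCCCn1c(N2CCN(C)CC2)nc2ccccc21`, 4200 nM

In a functional assay on ileum for inhibition of histamine H1 receptor (Cavia porcellus) (a higher number here means a weaker inhibitor, a lower number a stronger inhibitor), compound 3 stands highest of the three numbers; its nearest neighbour is compound 2 at 68 nM, and furthest away is compound 1 at 26 nM. Compound 4 `CN1CCN(c2nc3ccccc3n2CCOc2ccccc2)CC1` has not yet been measured in this assay. The change from compound 3 to compound 4: phenoxy in place of octyl on a saturated chain carbon, two bonds along the chain from an aromatic nitrogen.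

For the measured compounds named here, two measured steps bear on this. The step of a 160-fold higher number from compound 1 to compound 3 (2.21 log units; beyond the scatter) shows that lengthening the chain on the aromatic nitrogen gives a large rise; compound 4 moves the other way, to a much shorter chain carrying a phenoxy. The step of a 2.6-fold higher number from compound 1 to compound 2 (0.42 log units; beyond the scatter) shows that placing a heteroatom group in that chain costs a modest rise. A large fall from compound 3 is therefore expected in this assay, toward the region of compound 1 and compound 2 but probably not below them. Compound 4 is estimated at 60 nM, range 12 nM to 300 nM. This estimate means a step of a 70-fold lower number from compound 3 to compound 4 (1.85 log units; beyond the scatter).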

Compound 4, half-maximal inhibitory concentration: 6.9 nM
For compound 4 the middle estimate is 8.7-fold (0.94 log units) above the measured one; measured number below the stated range.
By their numbers in this assay, from the lowest: compound 4; then compound 1; then compound 2; then compound 3.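

In this assay, compound 4 is the strongest inhibitor of the four, with a 610-fold lower number from compound 3 to compound 4 (2.78 log units; beyond the scatter), a 9.9-fold lower number from compound 2 to compound 4 (0.99 log units; beyond the scatter) and a 3.8-fold lower number from compound 1 to compound 4 (0.58 log units; beyond the scatter). Until now, every listed change from compound 1 had raised the number, so compound 1 marked the lowest value at this position; phenoxy on a saturated chain carbon, two bonds along the chain from an aromatic nitrogen, goes beyond it and shows that a chain ending in an aromatic ring is accepted here. No measured evidence accounts for this gain.

The compounds shown do not separate the contribution of the ether oxygen from that of the phenyl ring, which a phenylpropyl chain would address. Also open, on these data alone, is how a fluorine or methoxy group on the phenoxy ring, or an amine in its place, would read in this assay.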